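Cyclohexylamino replacing dimethylamino at the shared core

A few compounds are considered here, and "the series" means these few. Any claim that something is new, unique, unknown or untested is made for them only; others in the source may bear on it.

Working notes on two measured compounds and one that is still open. Compound 1 `CCOC(=O)c1cnc(NC2CC2)n2nc(-c3ccco3)nc12` carries a cyclopropylamino group on the shared core, and in an assay on CHO cells for displacement of a labelled ligand from adenosine receptor A1 (Homo sapiens) (a higher number here means a weaker inhibitor, a lower number a stronger inhibitor), compound 1 gives 60.7 nM. Compound 2 `CCOC(=O)c1cnc(N(C)C)n2nc(-c3ccco3)nc12` carries a dimethylamino group at the same place, and in this assay compound 2 gives 13400 nM. For the measured compounds named here, the single step known so far is a 220-fold higher number from compound 1 to compound 2 (2.34 log units; beyond the scatter). On the two numbers shown, compound 2 stands at the highest, its nearest neighbour being compound 1.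

Compound 3 `CCOC(=O)c1cnc(NC2CCCCC2)n2nc(-c3ccco3)nc12` is the next member. Its difference from compound 2 is cyclohexylamino in place of dimethylamino on an aromatic carbon. Going by the values given here, the one measured step that bears on this change is the reverse of the move from compound 1 to compound 2, where the amino hydrogen was lost together with the cyclopropyl group and the number rose sharply. Compound 3 restores an amino hydrogen with a cycloalkyl group, so a large step toward a lower number in this assay is expected, though not necessarily the full reversal. Compound 3 is estimated at 150 nM in this assay, within 30 nM to 1000 nM, which means an expected step of an 89-fold lower number from compound 2 to compound 3 (1.95 log units; beyond the scatter).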

Compound 3, inhibition constant: 141 nM
Beside the measured number, compound 3's estimate is 1.1-fold (0.03 log units) above it, and the stated range covers the measured number.
By their numbers in this assay, from the lowest: compound 1; then compound 3; then compound 2.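

In this assay the change reads as a 95-fold lower number from compound 2 to compound 3 (1.98 log units; beyond the scatter) and shows that the high number of compound 2 does not hold for the position as such: cyclohexylamino on the same aromatic carbon returns the number to the range of compound 1. The comparison of the two cycloalkyl groups on the nitrogen gives a 2.3-fold higher number from compound 1 to compound 3 (0.37 log units; beyond the scatter) and is modest beside the step above, so the position tolerates cyclohexyl in place of cyclopropyl, although the two are not equivalent. Among the three compounds, the two with an amino hydrogen and a cycloalkyl ring give the lower numbers and none goes against this, yet compound 2 lacks both features at once, so the series does not assign the step to either one alone.

A methylamino group, which keeps the amino hydrogen without any ring, and an N-methyl-N-cyclohexylamino group, which keeps the ring without that hydrogen, would separate the two features, and an open-chain hexylamino group would test whether the ring itself matters. No measurement at hand accounts for the size of these steps.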